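Shuffling fluorine on the amide-bound ring

A few compounds are considered here, and "the series" means these few. Any claim that something is new, unique, unknown or untested is made for them only; others in the source may bear on it.

Compound 2 `COc1cccc2c1c(O)c(C(=O)N(C)c1cc(F)ccc1F)c(=O)n2C` gives 90% in a functional assay on the whole organism for inhibition, with Mus musculus as the target, at a dose of 1 mg/kg by the oral route (on this read-out higher numbers stand for more inhibition at the one dose given (going by the name of the read-out) and lower numbers for less inhibition), and compound 1 `COc1cccc2c1c(O)c(C(=O)N(C)c1ccccc1F)c(=O)n2C` gives 82% there, the two within the scatter of each other. Going by the values given here, the one step measured so far, a number 8 percentage points higher from compound 1 to compound 2 (within the scatter), is small. Compound 3 `COc1cccc2c1c(O)c(C(=O)N(C)c1ccc(F)cc1F)c(=O)n2C` differs from compound 2 by 2,4-difluorophenyl in place of 2,5-difluorophenyl on an amide-type nitrogen. Among the compounds with values here, no measured step moves a fluorine between ring positions, so the only guide is that adding fluorine changed little. Expected for compound 3 is 86% (range 70% to 96%), a step of a number 4 percentage points lower from compound 2 to compound 3 (within the scatter), not beyond the scatter.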

Compound 3, a percentage reported as inhibition, in the whole organism at one dose (the size of the read-out at that dose, not a potency): 88%
Beside the measured number, compound 3's estimate is 2 percentage points below it; low and high end bracket the measured number.
By their numbers in this assay, from the lowest: compounds 1, 3 and 2 (each within the scatter of the next).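

On the ring attached to the amide-type nitrogen, 2,4-difluorophenyl in place of 2,5-difluorophenyl gives a number 2 percentage points lower from compound 2 to compound 3 (within the scatter) in this assay, so moving a fluorine, and not only adding one, is now measured. Adding the second fluorine at another ring carbon gives a number 6 percentage points higher from compound 1 to compound 3 (within the scatter), and at this one dose no listed change separates the three compounds. Nothing available explains why these values lie so close.

Open, going by these compounds, is whether an amine or a methoxy group on this ring would hold the read-out. Also open, on these data alone, is how the three compounds compare at lower doses.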